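Replacing 2-cyclopropylethynyl with 2-carboxyethenyl

This account rests on a few compounds, and the source may have more. Where it says the series, first, only, none or still open, it means among the compounds named here.

Values in an ADME assay on MT2 cells (Homo sapiens) for cytotoxicity, read by XTT assay, with a stated time of 4 days; on this read-out higher numbers stand for lower toxicity in this test and lower numbers for higher toxicity in this test:
- compound 1 `Cc1cc(C#N)cc(C)c1Oc1ccc(N)c(Nc2ccc(C#N)cc2)n1`: > 100000 nM (a limit of the assay, not a number)
- compound 2 `Cc1cc(Br)cc(C)c1Oc1ccc(N)c(Nc2ccc(C#N)cc2)n1`: 9610 nM
- compound 3 `Cc1cc(C#CC2CC2)cc(C)c1Oc1ccc(N)c(Nc2ccc(C#N)cc2)n1`: 5710 nM

Compound 3 stands level with compound 2 within the scatter: a 1.7-fold lower number from compound 2 to compound 3 (0.23 log units; within the scatter). Both lie far from compound 1: an at least 10-fold lower number from compound 1 to compound 2 (1.01 log units; beyond the scatter) and an at least 17-fold lower number from compound 1 to compound 3 (1.24 log units; beyond the scatter).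

Compound 4 `Cc1cc(/C=C/C(=O)O)cc(C)c1Oc1ccc(N)c(Nc2ccc(C#N)cc2)n1` differs from compound 3 at one place: 2-carboxyethenyl in place of 2-cyclopropylethynyl on an aromatic carbon. Within the data shown here, no measured step introduces 2-carboxyethenyl. Among the measured compounds shown here, the only guide is that this aromatic carbon has carried large steps, as in an at least 17-fold lower number from compound 1 to compound 3 (1.24 log units; beyond the scatter), so a large move in this assay towards higher numbers is expected, though with wide uncertainty. The expected change is a 7.0-fold higher number from compound 3 to compound 4 (0.85 log units; beyond the scatter). The estimated value for compound 4 is 40000 nM, with an expected range of 10000 nM to 100000 nM.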

Compound 4, half-maximal cytotoxic concentration: 15700 nM
Estimate against measurement, compound 4: 2.5-fold (0.41 log units) above; low and high end bracket the measured number.
By their numbers in this assay, from the lowest: compounds 3, 2 and 4 (each within the scatter of the next, the first and the last beyond it). At a limit, above all of these: compound 1.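

In this assay, the oxygen-bearing 2-carboxyethenyl at this aromatic carbon shifts the number only modestly from the carbon-only 2-cyclopropylethynyl: a 2.7-fold higher number from compound 3 to compound 4 (0.44 log units; beyond the scatter). Against bromo, the printed step is a 1.6-fold higher number from compound 2 to compound 4 (0.21 log units; within the scatter). The acid-bearing chain does not reach the level of cyano, an at least 6.3-fold lower number from compound 1 to compound 4 (0.80 log units; beyond the scatter), and that step is read against a limit of the assay, not a number: the limit of > 100000 nM in this assay, at which 1 of the 4 values shown sits.

As far as these compounds go, it remains open whether a carboxylic acid set directly on the ring, a saturated propanoic acid chain or a primary amide would stay in this range or approach compound 1.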